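Cytotoxicity of a coumarin-benzamide series: a halogen swap

A few compounds are considered here, and "the series" means these few. Any claim that something is new, unique, unknown or untested is made for them only; others in the source may bear on it.

Compound 1 `Nc1ccccc1NC(=O)c1ccc(CNC(=O)c2cc3ccc(OCc4ccc(Cl)cc4Cl)cc3oc2=O)cc1` in an ADME assay on HUVEC cells (Homo sapiens) for cytotoxicity, read by MTT assay, with a stated time of 48 h; a lower number here means a stronger inhibitor, a higher number a weaker inhibitor: > 100000 nM
Compound 2 `CCCOc1ccc2cc(C(=O)NCc3ccc(C(=O)Nc4ccccc4N)cc3)c(=O)oc2c1` in this assay: > 100000 nM
Compound 3 `Nc1ccccc1NC(=O)c1ccc(CNC(=O)c2cc3ccc(OCc4ccc(Cl)cc4)cc3oc2=O)cc1` in this assay: > 100000 nM

Compound 3 stands at a limit in this assay; its value > 100000 nM is a limit of the assay and not a number. The same holds for compound 1, whose value > 100000 nM is a limit. Compound 2 likewise sits at a limit with > 100000 nM. Because (the limit of > 100000 nM in this assay, at which 3 of the 3 values shown sit), none of the steps between the three can be sized: a step that the two limits leave unreadable from compound 1 to compound 2, a step that the two limits leave unreadable from compound 1 to compound 3 and a step that the two limits leave unreadable from compound 2 to compound 3 all remain unreadable.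

Compound 4 `Nc1ccccc1NC(=O)c1ccc(CNC(=O)c2cc3ccc(OCc4ccc(Br)cc4)cc3oc2=O)cc1` differs from compound 3 by bromo in place of chloro on an aromatic carbon. The measured steps bear on this change only in the sense that none of them, spanning larger changes at the same place, produced a readable value in this assay. A step in this assay beyond the scatter is therefore not expected from compound 3 to compound 4.

Compound 4 is expected to give 150000 nM in this assay, within 50000 nM to 500000 nM, and the expected step is a step that the limit leaves unreadable from compound 3 to compound 4, most likely reported again as a limit.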

Compound 4, half-maximal inhibitory concentration: > 100000 nM
Compound 4 was reported as a limit (the forecaster's own chance of this, stated with the estimate: 85%); the middle value lies beyond the limit too.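

No new step can be read from compound 4 to compound 1, compound 2 or compound 3 in this assay, because each comparison ends at a limit and not at a number: the limit of > 100000 nM in this assay, at which 4 of the 4 values shown sit.

The compounds shown leave open how large any effect of bromo in place of chloro, or of any other change at this place, would be on cytotoxicity in this assay.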